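Trifluoromethyl replacing dimethylcarbamoyl on a phenoxyacetic acid alkyne

The source may hold more compounds than are shown below. What is called first, only, known or untested is meant among the compounds shown, and "the series" means these compounds.

Three compounds sharing a phenoxyacetic acid joined through an alkyne to a second aromatic ring have been measured in an assay on CHO cells for displacement of a labelled ligand from prostaglandin D2 receptor 2 (Homo sapiens), read by scintillation counting; on this read-out higher numbers stand for weaker inhibition and lower numbers for stronger inhibition. Compound 1 `CN(C)C(=O)c1cccc(C#Cc2cc(Cl)ccc2OCC(=O)O)c1` gives 52 nM. Compound 2 `CCCS(=O)(=O)c1cccc(C#Cc2cc(F)ccc2OCC(=O)O)c1` gives 65 nM, and compound 3 `O=C(O)COc1ccc(Cl)cc1C#Cc1ccc(F)cc1F` gives 101 nM; both of these numbers lie within the usual scatter of the value for compound 1, so no ordering among the three can be read from the data.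

Compound 4 `O=C(O)COc1ccc(Cl)cc1C#Cc1cccc(C(F)(F)F)c1` has not yet been measured. It differs from compound 1 in one place: trifluoromethyl in place of dimethylcarbamoyl on an aromatic carbon. Among the measured compounds shown here, no measured pair in this set shows this change or any other single change, so there is no precedent from which to read a direction. The other two compounds, which carry quite different groups on the same ring, stay close to compound 1 in this assay, and a similar outcome is expected here.

Compound 4 is therefore estimated at 60 nM, within a range of 20 nM to 180 nM. The expected step of a 1.2-fold higher number from compound 1 to compound 4 (0.06 log units; within the scatter) is thus not expected to exceed the scatter.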

Compound 4, inhibition constant: 92 nM
For compound 4 the middle estimate is 1.5-fold (0.19 log units) below the measured one, within the range that was stated.
By their numbers in this assay, from the lowest: compounds 1, 2, 4 and 3 (each within the scatter of the next).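

In this assay, the change from dimethylcarbamoyl to trifluoromethyl gives a 1.8-fold higher number from compound 1 to compound 4 (0.25 log units; within the scatter), so this first single-place comparison in the set stays within the scatter. On this aromatic carbon, a group with no hydrogen-bond acceptor and no carbonyl can therefore stand in place of one that has both, with no difference that this read-out can resolve. Nothing measured here bears on why the two groups give values this close.

The compounds shown leave open whether an amine, a carboxylic acid or a longer alkyl chain on this aromatic carbon would also stay within the scatter of compound 1 or would give a step beyond it. Equally open, from the compounds shown here alone, is what a plain hydrogen at this place would give.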